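A few compounds are considered here, and "the series" means these few. Any claim that something is new, unique, unknown or untested is made for them only; others in the source may bear on it.

Measured in a functional assay on A-375 cells (Homo sapiens) for antiproliferative activity, read by MTT assay, with a stated time of 24 h; a higher number here means a weaker inhibitor, a lower number a stronger inhibitor:
- compound 1 `C#CCOc1ccc2c(=O)c(-c3cc(OC)c(OC)cc3OC)coc2c1`: 3680 nM
- compound 2 `COc1cc(OC)c(-c2coc3cc(OCc4ccccc4)ccc3c2=O)cc1OC`: 1640 nM
- compound 3 `COc1cc(OC)c(-c2coc3cc(OCC(=O)c4cccc(C(F)(F)F)c4)ccc3c2=O)cc1OC`: > 10000 nM

Compound 3 has no exact number, and its entry of > 10000 nM is a limit of the assay. Compound 4 `COc1cc(OC)c(-c2coc3cc(OCc4ccc(Br)cc4)ccc3c2=O)cc1OC` has not yet been measured. It differs from compound 3 as follows: 4-bromophenyl in place of (3-(trifluoromethyl)phenyl)carbonyl on a saturated chain carbon bound to an oxygen on an aromatic ring. That change removes the carbonyl and leaves an aromatic ring directly on the chain carbon, as in compound 2.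

The nearest guide is an at least 6.0-fold higher number from compound 2 to compound 3 (0.78 log units; beyond the scatter), where (3-(trifluoromethyl)phenyl)carbonyl replaced phenyl. Also relevant is a 2.2-fold lower number from compound 1 to compound 2 (0.35 log units; beyond the scatter), where phenyl replaced ethynyl. For the measured compounds named here, no measured compound carries bromine, so the effect of that atom remains open. Compound 4 should therefore fall close to compound 2, which gives 1640 nM. Compound 4 should also fall clearly lower than the limit of compound 3 in this assay. The expected change, beyond the scatter, is an at least 6.2-fold lower number from compound 3 to compound 4 (0.79 log units; beyond the scatter). For compound 4 the estimated value is 1600 nM, with an expected range from 500 nM to 5000 nM.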

Compound 4, half-maximal inhibitory concentration: 1000 nM
For compound 4 the middle estimate is 1.6-fold (0.20 log units) above the measured one; the measured number falls inside the stated range.
By their numbers in this assay, from the lowest: compounds 4 and 2 (each within the scatter of the next); then compound 1. At a limit, above all of these: compound 3.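

In this assay, putting 4-bromophenyl in place of (3-(trifluoromethyl)phenyl)carbonyl gives an at least 10-fold lower number from compound 3 to compound 4 (1.00 log units; beyond the scatter), a step that is only a bound because the entry for compound 3 is a limit: the limit of > 10000 nM in this assay, at which 1 of the 4 values shown sits. Bromo in place of hydrogen on an aromatic carbon, a change the earlier compounds did not cover, gives a 1.6-fold lower number from compound 2 to compound 4 (0.21 log units; within the scatter). Putting 4-bromophenyl in place of ethynyl gives a 3.7-fold lower number from compound 1 to compound 4 (0.57 log units; beyond the scatter), so an aromatic ring directly on the chain carbon, in compound 2 and in compound 4, twice gives a lower number than ethynyl, while compound 3, with its carbonyl, goes against this.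

The compounds shown do not separate the carbonyl from the trifluoromethyl of compound 3, as the two change together. From the compounds shown here alone, how an amine, a carboxylic acid or a longer chain would read at this place also remains open.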